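The source may hold more compounds than are shown below. What is called first, only, known or untested is meant among the compounds shown, and "the series" means these compounds.

Compound 1 `Nc1nc(Nc2ccccc2)sc1C(=O)c1cccc(F)c1`: 4100 nM
Compound 2 `Nc1nc(Nc2ccc(S(N)(=O)=O)cc2)sc1C(=O)c1cccnc1`: > 30000 nM
Compound 3 `Nc1nc(Nc2ccc(S(N)(=O)=O)cc2)sc1C(=O)c1ccccc1`: not yet measured

In a functional assay on GC-2 cells (Mus musculus) for cytotoxicity, read by MTT assay, with a stated time of 72 h (on this read-out lower numbers stand for stronger inhibition and higher numbers for weaker inhibition), compound 2 reads > 30000 nM, which is a limit of the assay and not a number. Compound 3 differs from it at one place: phenyl in place of pyridin-3-yl on a carbonyl carbon. Among the compounds with values here, no measured pair isolates this change. Compound 1, which gives 4100 nM, also has a carbon-only ring on its carbonyl, but it differs elsewhere too. A modest shift toward stronger inhibition is therefore expected, with the estimated step of an at least 1.8-fold lower number from compound 2 to compound 3 (0.27 log units; that floor lies within the scatter). The estimated value for compound 3 is 16000 nM, with an expected range from 6000 nM to 40000 nM.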

Compound 3, half-maximal inhibitory concentration: 6100 nM
Beside the measured number, compound 3's estimate is 2.6-fold (0.42 log units) above it; measured number inside the range.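

In this assay, within the data shown here, phenyl in place of pyridin-3-yl on a carbonyl carbon gives an at least 4.9-fold lower number from compound 2 to compound 3 (0.69 log units; beyond the scatter), the first reading of this change on its own. Exchanging this one ring is enough to bring the read-out from the limit into a measurable value. The reading for compound 2 is a limit of the assay and not a number, so the step gives only a floor for the true size: the limit of > 30000 nM in this assay, at which 1 of the 3 values shown sits.

On these data alone, what remains open is how far this position tolerates other groups, such as a methoxy group or a carboxylic acid on the phenyl ring.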